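The source may hold more compounds than are shown below. What is called first, only, known or untested is meant among the compounds shown, and "the series" means these compounds.

Measured in a functional assay on MCF7 cells (Homo sapiens) for inhibition, read by MTT assay, with a stated time of 5 days; a higher number here means a weaker inhibitor, a lower number a stronger inhibitor:
Compound 1 `Cc1cc(Nc2nc(NCc3ccc(F)cc3F)nc3[nH]ncc23)n[nH]1` gives 670 nM
Compound 2 `Cc1cc(Nc2nc(NCc3ccc(F)cc3F)nc3c2cnn3CC(C)(C)O)n[nH]1` gives 160 nM

Of the two compounds measured, compound 2 has the lower number, at 160 nM. Compound 3 `Cc1cc(Nc2nc(NCc3ccc(F)cc3F)nc3c2cnn3C2CCCCC2)n[nH]1` carries cyclohexyl in place of 2-hydroxy-2-methylpropyl on an aromatic nitrogen. Among the measured compounds shown here, only one measured step bears on this change, the placing of 2-hydroxy-2-methylpropyl on that nitrogen in place of hydrogen, and it is modest but beyond the scatter. Since a 4.2-fold lower number from compound 1 to compound 2 (0.62 log units; beyond the scatter) compares a substituted nitrogen with an unsubstituted one, and compound 3 is substituted there too, compound 3 is expected to fall nearer compound 2 than compound 1. As far as these compounds go, the data hold no comparison of one substituent with another on this nitrogen, and none of a ring with an open chain, so the direction of the change remains open. In this assay the expected step stays within the scatter, and it is estimated as a 1.3-fold higher number from compound 2 to compound 3 (0.10 log units; within the scatter). For compound 3 the estimated value is 200 nM, with an expected range of 60 nM to 650 nM.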

Compound 3, half-maximal inhibitory concentration: 810 nM
The estimate for compound 3 lay 4.1-fold (0.61 log units) below the measured number, and the stated range ends below it.
By their numbers in this assay, from the lowest: compound 2; then compounds 1 and 3 (each within the scatter of the next).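

In this assay, the new compound shows that filling this aromatic nitrogen does not in itself bring the gain seen with compound 2. Replacing 2-hydroxy-2-methylpropyl with cyclohexyl gives a 5.1-fold higher number from compound 2 to compound 3 (0.70 log units; beyond the scatter) and removes that gain, while cyclohexyl in place of hydrogen gives only a 1.2-fold higher number from compound 1 to compound 3 (0.08 log units; within the scatter) and so leaves compound 3 within the scatter of the unsubstituted compound 1. At this position it is therefore the identity of the group that matters, not merely the presence of one, and of the three compounds only compound 2, with 2-hydroxy-2-methylpropyl, stands apart from the others; nothing measured here accounts for the difference between the two groups.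

The compounds shown leave open whether the lower number of compound 2 goes with the hydroxy group or with the open chain, as the two change together in this step. A plain 2-methylpropyl chain, a cyclohexyl ring bearing a hydroxy group, or an amine in the same place would begin to separate these possibilities.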